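Anilide series: replacing 4-methoxyphenyl on the amide nitrogen

The compounds below may be only part of what the source reports. "The series", "measured", "known", "first", "only" and "open" are said of these compounds alone.

Compound 1 `COc1ccc(NC(=O)C2Cc3cc(OC)c(OC)cc3C2=O)cc1` is the reference point. Among the measured compounds shown here, in a physicochemical assay, with a stated time of 30 min (a higher number here means a weaker inhibitor, a lower number a stronger inhibitor), compound 1 gives 49.5 ug/mL, the highest of the two numbers measured so far. Its nearest neighbour is compound 2 `COc1cc2c(cc1OC)C(=O)C(C(=O)Nc1ccccc1C)C2`, which in this assay gives 43.7 ug/mL; the step of a 1.1-fold lower number from compound 1 to compound 2 (0.05 log units; within the scatter) is within the scatter, so the two values are not distinguishable.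

Compound 3 `COc1cc2c(cc1OC)C(=O)C(C(=O)Nc1ccccc1F)C2` has not been measured. Its difference from compound 1 is 2-fluorophenyl in place of 4-methoxyphenyl on an amide-type nitrogen.

For the measured compounds named here, the only measured step that bears on this change is the one from compound 1 to compound 2, which also swaps the 4-methoxyphenyl on the amide-type nitrogen for a 2-substituted phenyl and produced no movement beyond the scatter. Going by the values given here, no measured step carries a 2-fluorophenyl, so the comparison rests on this single step. The expectation is therefore a step of a 1.1-fold lower number from compound 1 to compound 3 (0.04 log units; within the scatter) for compound 3, which is no change beyond the scatter.

Compound 3 is estimated at 45 ug/mL in this assay, with a range from 25 ug/mL to 85 ug/mL.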

Compound 3, half-maximal inhibitory concentration: 75.7 ug/mL
The estimate for compound 3 lay 1.7-fold (0.23 log units) below the measured number, and the stated range covers the measured number.
By their numbers in this assay, from the lowest: compounds 2, 1 and 3 (each within the scatter of the next).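

In this assay, 2-fluorophenyl on the amide-type nitrogen gives a 1.5-fold higher number from compound 1 to compound 3 (0.18 log units; within the scatter), so a second replacement of 4-methoxyphenyl at this place, after the 2-methylphenyl of compound 2, also stays inside the scatter. The series now also has a direct comparison between the two 2-substituted phenyl groups: fluoro in place of methyl on an aromatic carbon gives a 1.7-fold higher number from compound 2 to compound 3 (0.24 log units; within the scatter), which is also inside the scatter. Compounds 1, 2 and 3 are therefore not separated by this assay, and across these three compounds the choice among 4-methoxyphenyl, 2-methylphenyl and 2-fluorophenyl makes no distinguishable difference; no accompanying measurement is available to interpret the small steps among them.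

As far as these compounds go, all three groups at this place are phenyl rings with no net charge, so it remains open whether an amine or a carboxylic acid on the phenyl ring, or a longer chain in its place, would move the number beyond the scatter. The compounds shown also leave open what a methyl group in place of the amide hydrogen would do, and whether the methoxy groups on the shared core can be exchanged for other groups, such as hydroxyl.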